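The source may report more compounds than this note shows. Statements on the series, on what has been measured and on what is new or still open speak of the compounds shown alone.

Compounds measured in an assay on isolated protein for inhibition of Fatty-acid amide hydrolase 1 (Rattus norvegicus); a lower number here means a stronger inhibitor, a higher number a weaker inhibitor:

Compound 1 `CC(=O)c1coc(C(=O)CCCCCCc2ccccc2)n1`: 2 nM
Compound 2 `O=C(CCCCCCc1ccccc1)c1nc(C(F)(F)F)co1`: 3.7 nM

Among the measured compounds shown here, compound 2 stands at the higher of the two numbers, but its only neighbour is compound 1, and a 1.9-fold higher number from compound 1 to compound 2 (0.27 log units; within the scatter) lies within the scatter, so the two compounds cannot be told apart on this assay. The unmeasured compound 3 `COc1coc(C(=O)CCCCCCc2ccccc2)n1` keeps the shared core with its phenyl-capped chain and changes only the small group on the ring: methoxy in place of trifluoromethyl on an aromatic carbon.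

For the measured compounds named here, only one measured step bears on this change, a 1.9-fold higher number from compound 1 to compound 2 (0.27 log units; within the scatter), and it shows that swapping acetyl for trifluoromethyl at this position leaves the number essentially unchanged. Methoxy, however, is neither of these two groups, and no measured pair shows how the core responds to it. The expectation is therefore a step that may reach beyond the scatter toward a higher number, with wide uncertainty, estimated as a 4.1-fold higher number from compound 2 to compound 3 (0.61 log units; beyond the scatter). Compound 3 is expected to give about 15 nM in this assay, within a range of 3 nM to 80 nM.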

Compound 3, inhibition constant: 740 nM
The estimate for compound 3 lay 49-fold (1.69 log units) below the measured number, and the stated range ends below it.
By their numbers in this assay, from the lowest: compounds 1 and 2 (each within the scatter of the next); then compound 3.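

In this assay the carbon next to the ring nitrogen turns out not to accept just any small group: methoxy in place of trifluoromethyl makes the compound a far weaker inhibitor (a 200-fold higher number from compound 2 to compound 3 (2.30 log units; beyond the scatter)), and methoxy in place of acetyl does much the same (a 370-fold higher number from compound 1 to compound 3 (2.57 log units; beyond the scatter)). Among the compounds shown here, until now the only swap at this carbon, between acetyl and trifluoromethyl, lay within the scatter, so the position could have looked forgiving; that flat result now holds for those two groups only, and the choice of group here can decide between a strong and a weak inhibitor. Nothing at hand explains why methoxy parts so sharply from the other two groups.

The three compounds cannot show whether this large step belongs to methoxy alone or would also appear with other groups at this carbon, such as an amine, a nitrile, a carboxylic acid or a plain methyl. They also leave open whether a longer ether such as ethoxy would follow methoxy, and whether the same step would appear with a shorter chain in place of the phenyl-capped one.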